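The source may hold more compounds than are shown below. What is called first, only, known or untested is meant among the compounds shown, and "the series" means these compounds.

Three compounds have numbers in a functional assay on MCF7 cells (Homo sapiens) for cytotoxicity, read by CellTiter-Glo, with a stated time of 5 days; on this read-out higher numbers stand for weaker inhibition and lower numbers for stronger inhibition:
compound 1 `COC/C(=C(/c1ccc(/C=C/C(=O)O)cc1)c1ccc2[nH]ncc2c1)c1ccccc1` gives 88 nM;
compound 2 `O=C(O)/C=C/c1ccc(/C(=C(/CCF)c2ccccc2)c2ccc3[nH]ncc3c2)cc1` gives 2.1 nM;
compound 3 `O=C(O)/C=C/c1ccc(/C(=C(/CCCl)c2ccccc2)c2ccc3[nH]ncc3c2)cc1` gives 9 nM.

Compound 3 stands second highest of the three: a 4.3-fold higher number from compound 2 to compound 3 (0.63 log units; beyond the scatter), while a 9.8-fold lower number from compound 1 to compound 3 (0.99 log units; beyond the scatter). Compound 4 `CC(C)/C(=C(/c1ccc(/C=C/C(=O)O)cc1)c1ccc2[nH]ncc2c1)c1ccccc1` differs from compound 3 by isopropyl in place of 2-chloroethyl on a double-bonded chain carbon bound to an aromatic carbon and a double-bonded chain carbon. Among the compounds with values here, no measured step swaps a halogen-bearing chain for an all-carbon one. Within the data shown here, the steps that bear on it, a 42-fold lower number from compound 1 to compound 2 (1.62 log units; beyond the scatter) and a 9.8-fold lower number from compound 1 to compound 3 (0.99 log units; beyond the scatter), show that a change at this place on the chain can move the number a great deal, and a 4.3-fold higher number from compound 2 to compound 3 (0.63 log units; beyond the scatter) shows that exchanging the halogen alone moves it. With no halogen left, a modest rise in this assay is expected: a 2.8-fold higher number from compound 3 to compound 4 (0.44 log units; beyond the scatter). Compound 4 is therefore estimated at 25 nM, range 6 nM to 100 nM.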

Compound 4, half-maximal inhibitory concentration: 4 nM
The estimate for compound 4 lay 6.3-fold (0.80 log units) above the measured number; the whole stated range lies above it.
By their numbers in this assay, from the lowest: compounds 2 and 4 (each within the scatter of the next); then compound 3; then compound 1.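

In this assay a halogen is not needed at this place on the double-bonded chain carbon: the all-carbon isopropyl gives a 2.3-fold lower number from compound 3 to compound 4 (0.35 log units; beyond the scatter) and a 1.9-fold higher number from compound 2 to compound 4 (0.28 log units; within the scatter), the second step lying within the scatter. Replacing methoxymethyl with isopropyl gives a 22-fold lower number from compound 1 to compound 4 (1.34 log units; beyond the scatter), so among these four compounds the highest number belongs to the methoxymethyl chain, not to the other chain without a halogen.

From the compounds shown here alone, whether a longer chain, a cyclopropyl group or an amine here would keep the number this low stays open. The data at hand offer no explanation for the differences between these groups.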